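The source may report more compounds than this note shows. Statements on the series, on what has been measured and on what is new or still open speak of the compounds shown alone.

Compound 1 `COc1ccc(CS(=O)(=O)/C=C/c2ccccc2OC)cc1N` gives 7500 nM in a functional assay on DU-145 cells (Homo sapiens) for cytotoxicity, read by trypan blue exclusion, with a stated time of 96 h; on this read-out lower numbers stand for stronger inhibition and higher numbers for weaker inhibition. Compound 3 `COc1ccc(OC)c(/C=C/S(=O)(=O)Cc2ccc(OC)c(N)c2)c1` gives 750 nM in this assay. The step of a 10-fold lower number from compound 1 to compound 3 (1.00 log units; beyond the scatter) rests on a single change, (methoxy in place of hydrogen on an aromatic carbon). Compound 2 `COc1ccc(CS(=O)(=O)/C=C/c2c(OC)cccc2OC)cc1[N+](=O)[O-]` gives 20000 nM in this assay, the highest number of the three; the difference between the cores of compound 1 and compound 2 is not broken down here. Compound 4 `COc1cc(OC)c(/C=C/S(=O)(=O)Cc2ccc(OC)c([N+](=O)[O-])c2)c(OC)c1` awaits measurement and differs from compound 2 by methoxy in place of hydrogen on an aromatic carbon. This is the same kind of change as that from compound 1 to compound 3, but not the same: in compound 3 the entering methoxy is meta to a large group and para to a methoxy group, whereas in compound 4 it is meta to two methoxy groups and para to a large group. A step of a 6.7-fold lower number from compound 2 to compound 4 (0.82 log units; beyond the scatter) is expected, judged against a 10-fold lower number from compound 1 to compound 3 (1.00 log units; beyond the scatter) with some allowance for the differing surroundings. For compound 4 the expected value in this assay is 3000 nM, within 1000 nM to 10000 nM.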

Compound 4, half-maximal inhibitory concentration: 2500 nM
For compound 4 the middle estimate is 1.2-fold (0.08 log units) above the measured one, within the range that was stated.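

Methoxy in place of hydrogen on an aromatic carbon gives an 8.0-fold lower number from compound 2 to compound 4 (0.90 log units; beyond the scatter) in this assay. Set beside the earlier step, the change carries over between the two cores at much the same size: the same change on two cores in this assay, a 10-fold lower number (1.00 log units; beyond the scatter) from compound 1 to compound 3 and an 8.0-fold lower number (0.90 log units; beyond the scatter) from compound 2 to compound 4, 1.3-fold (0.10 log units) apart, within the scatter of two such steps. This rests on two pairs only, with the entering methoxy in different surroundings in each, so it does not show that the step would hold on other cores or at other places on the ring, and it gives no reason for the step.

Still open, on these data alone, is whether a longer chain such as ethoxy at the same place gives a step of like size. The same holds for a hydroxy group or a carboxylic acid there.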